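The source may hold more compounds than are shown below. What is called first, only, known or untested is meant among the compounds shown, and "the series" means these compounds.

In a functional assay on CHO cells for antagonist activity at 5-hydroxytryptamine receptor 6 (Homo sapiens), read by FLIPR (a higher number here means a weaker inhibitor, a lower number a stronger inhibitor), compound 1 `COc1ccc(S(=O)(=O)N2CC(C(=O)N(C)C3CCN(C)CC3)c3ccccc32)c2ccccc12` gives 7.94 nM. For the measured compounds named here, compound 2 `CN1CCC(N(C)C(=O)C2CN(S(=O)(=O)c3cccc4ccccc34)c3ccccc32)CC1` gives 31.6 nM in this assay, and it stands as the higher of the two numbers measured so far; the step of a 4.0-fold higher number from compound 1 to compound 2 (0.60 log units; beyond the scatter) is the only one recorded between them. Compound 3 `Cc1c(S(=O)(=O)N2CC(C(=O)N(C)C3CCN(C)CC3)c3ccccc32)sc2ccc(Cl)cc12` has not yet been measured. It differs from compound 2 in that 5-chloro-3-methyl-1-benzothiophen-2-yl in place of naphthalen-1-yl on a sulfonyl sulfur — a 5-chloro-3-methyl-1-benzothiophen-2-yl group in place of naphthalen-1-yl on the sulfonyl sulfur, whose other neighbour is the sulfonamide nitrogen in a ring. Going by the values given here, the one measured step, from compound 1 to compound 2, concerned a methoxy group on the aromatic part attached to the sulfonyl sulfur and was modest in size; it shows that the aryl part is felt in this assay, but it does not address an exchange of the whole aromatic system. On that thin basis compound 3 is expected to land near compound 2, with a step of about a 1.6-fold lower number from compound 2 to compound 3 (0.20 log units; within the scatter), leaning slightly toward a lower number. The estimate for compound 3 in this assay is therefore 20 nM, with a range from 5 nM to 80 nM.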

Compound 3, inhibition constant: 63.1 nM
The estimate for compound 3 lay 3.2-fold (0.50 log units) below the measured number, within the range that was stated.
By their numbers in this assay, from the lowest: compound 1; then compounds 2 and 3 (each within the scatter of the next).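

In this assay, replacing naphthalen-1-yl on the sulfonyl sulfur with 5-chloro-3-methyl-1-benzothiophen-2-yl gives a 2.0-fold higher number from compound 2 to compound 3 (0.30 log units; within the scatter), so the two numbers cannot be told apart. The earlier step touched only a methoxy group on the aryl part, whereas this one exchanges the whole aromatic system, putting one five-membered aromatic ring with a hetero atom and one six-membered aromatic ring of carbon only where two six-membered aromatic rings of carbon only stood, and the result shows that this position tolerates that exchange, at least for this pair. No measurement shown here explains why the two groups read alike in this assay.

The ring sulfur, the chlorine and the methyl all enter together in this single change, so the compounds shown cannot separate what each contributes, and a 1-benzothiophen-2-yl group carrying neither chlorine nor methyl would be needed to do so. On these data alone, it also remains open how a plain phenyl, a pyridine ring or an aryl group bearing a carboxylic acid or an amine would read on the same sulfonyl sulfur.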